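Swapping an Oxazole for a Cyanophenyl on the Amide

The source may report more compounds than this note shows. Statements on the series, on what has been measured and on what is new or still open speak of the compounds shown alone.

Of the compounds shown here, three built on one shared core have been tested in a toxicity assay on THP-1 cells (Homo sapiens) for inhibition; on this read-out higher numbers stand for lower toxicity in this test and lower numbers for higher toxicity in this test. Compound 1 `COc1ccc(-c2cnc(NC(=O)c3cnco3)n2C)cc1` gives > 100000 nM in this assay, and this is a limit of the test rather than a measured number. Compound 2 `Cn1c(-c2cccc(C#N)c2)cnc1NC(=O)c1ccc(F)cc1` gives > 100000 nM in this assay, again a limit. Compound 3 `Cn1c(-c2ccc(C#N)cc2)cnc1NC(=O)c1ncc[nH]1` gives > 100000 nM in this assay, also a limit. Compound 1 therefore stands exactly where the others stand: the limit of > 100000 nM in this assay, at which 3 of the 3 values shown sit. None of the three shows measurable toxicity within the tested range, so no difference between them can be read from these numbers.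

Compound 4 `COc1ccc(-c2cnc(NC(=O)c3ccc(C#N)cc3)n2C)cc1` has not yet been measured. It differs from compound 1 in one place: 4-cyanophenyl in place of 1,3-oxazol-5-yl on a carbonyl carbon. Among the measured compounds shown here, no step between two measured compounds is available here, so no measured change can be quoted. For the measured compounds named here, since every value so far sits at the same limit, the expectation is for no step beyond the scatter in either direction, with the test most likely again reporting only a limit. Compound 4 is expected at about 100000 nM, with a range from 30000 nM to 300000 nM. This estimate means a step of a number no higher from compound 1 to compound 4 (the limit leaves the size open), expected to be none beyond the scatter.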

Compound 4, half-maximal cytotoxic concentration: > 100000 nM
Compound 4 was reported as a limit; the forecaster's own chance of this, stated with the estimate: 75%; the middle value lies on the limit itself.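

Compound 1 and compound 4 are both reported only as limits in this assay, so no step between them can be read: the limit of > 100000 nM in this assay, at which 4 of the 4 values shown sit.

The compounds shown leave open whether 4-cyanophenyl and 1,3-oxazol-5-yl on the carbonyl carbon differ at all in this assay, and what toxicity any of these compounds would show past that limit.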